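Amide nitrogen methylation in a potassium channel inhibitor series

The source may report more compounds than this note shows. Statements on the series, on what has been measured and on what is new or still open speak of the compounds shown alone.

Compound 2 `C[C@H](NC(=O)c1cc(C(F)(F)F)nn1C)c1nc(-c2cccc(F)c2)no1` carries the only numerical result in an assay on T-REx-293 cells for inhibition of potassium channel subfamily T member 1 (Homo sapiens), read by patch clamp (on this read-out lower numbers stand for stronger inhibition and higher numbers for weaker inhibition), where compound 2 gives 136 nM. Compound 1 `Cc1cccc(-c2nnc([C@H](C)NC(=O)c3cc(C4CC4)nn3C)o2)c1` returns only a limit of the assay in this assay, > 30000 nM. Of the two values shown, one sits at the limit of > 30000 nM in this assay, at which 1 of the 2 values shown sits. Compound 3 `C[C@@H](c1nc(-c2cccc(F)c2)no1)N(C)C(=O)c1cc(C(F)(F)F)nn1C` differs from compound 2 by methyl in place of hydrogen on an amide-type nitrogen. Going by the values given here, no step between measured compounds is available to calibrate this change. The expected step from compound 2 to compound 3 in this assay is an 11-fold higher number from compound 2 to compound 3 (1.04 log units; beyond the scatter), towards weaker inhibition and beyond the usual scatter. Compound 3 is estimated to give 1500 nM in this assay, within 300 nM to 10000 nM.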

Compound 3, half-maximal inhibitory concentration: 6490 nM
For compound 3 the middle estimate is 4.3-fold (0.64 log units) below the measured one, and the stated range covers the measured number.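

In this assay, going by these compounds alone, methyl in place of hydrogen on an amide-type nitrogen gives a 48-fold higher number from compound 2 to compound 3 (1.68 log units; beyond the scatter), towards weaker inhibition and the first reading of this position. The amide hydrogen therefore cannot be replaced by methyl without a large loss on the core of compound 2, although compound 3 still gives a true number, 6490 nM. The data shown give no cause for this loss.

From the compounds shown here alone, whether an ethyl group or a longer chain on the same nitrogen would weaken inhibition further remains open. So does whether this step carries over to other cores.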